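The compounds below may be only part of what the source reports. "The series", "measured", "known", "first", "only" and "open" are said of these compounds alone.

Compound 1, `CCOC(=O)c1sc2nc(-c3ccccc3)cc(C(F)(F)F)c2c1N`, gives > 20000 nM in an ADME assay on Huh-7 cells (Homo sapiens) for cytotoxicity, read by MTT assay, with a stated time of 72 h; a lower number here means that less compound is tolerated, a higher number that more compound is tolerated; this is a limit of the assay, not a number.
Compound 2, `Nc1c(C(=O)NCc2ccccc2)sc2nc(-c3ccccc3)cc(C(F)(F)F)c12`, gives > 20000 nM in this assay; this too is a limit of the assay.

Compound 2 therefore stands only at a limit: neither of the two values shown is a number, and both sit at the same limit, as the limit of > 20000 nM in this assay, at which 2 of the 2 values shown sit, states. For the measured compounds named here, the one measured step, a step that the two limits leave unreadable from compound 1 to compound 2, cannot be read for size, since both of its ends are limits. The change now considered is thiophen-2-yl in place of phenyl on a saturated chain carbon bound to an amide-type nitrogen, giving compound 3, `Nc1c(C(=O)NCc2cccs2)sc2nc(-c3ccccc3)cc(C(F)(F)F)c12`. No measured step bears on this exchange, and the only step shown, a step that the two limits leave unreadable from compound 1 to compound 2, is itself unreadable, so there is no ground to expect a step beyond the scatter in either direction in this assay. The most likely outcome is that compound 3 also returns a limit. The expected step is a step that the limit leaves unreadable from compound 2 to compound 3, which amounts to no change beyond the scatter. Compound 3 is thus estimated at 30000 nM, with a range from 10000 nM to 100000 nM.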

Compound 3, half-maximal cytotoxic concentration: > 20000 nM
Compound 3 gave a limit, no number; the forecaster's own chance of this, stated with the estimate: 80%; the middle value is on the limit's open side.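

Compound 3 gives > 20000 nM in this assay, which is a limit and not a number. The steps linking compound 1, compound 2 and compound 3 therefore cannot be read for size. Left open is the concentration at which any of these compounds harms the cells, and whether either exchange shifts it: the limit of > 20000 nM in this assay, at which 3 of the 3 values shown sit.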